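Isopropyl for Phenyl on the Core of Compound 3

The source may hold more compounds than are shown below. What is called first, only, known or untested is meant among the compounds shown, and "the series" means these compounds.

Of the compounds shown here, three sharing one core have been measured in a functional assay on HEK293 cells for activation of melanin-concentrating hormone receptor 1 (Homo sapiens), read by inositol phosphate accumulation; on this read-out lower numbers stand for an effect already at smaller amounts and higher numbers for an effect only at larger amounts of compound. Compound 1 `CCCc1cc(NC)c2cc(NC(=O)/C=C/c3ccc(C(F)(F)F)cc3)ccc2n1` gives 150 nM in this assay. Compound 2 `CCc1cc(N)c2cc(NC(=O)/C=C/c3ccc(C(F)(F)F)cc3)ccc2n1` gives 110 nM. Compound 3 `Nc1cc(-c2ccccc2)nc2ccc(NC(=O)/C=C/c3ccc(C(F)(F)F)cc3)cc12` gives 6600 nM, the highest of the three numbers, beyond the scatter from both others; it arose from compound 2 by phenyl in place of ethyl on an aromatic carbon, a change that brought a 60-fold higher number from compound 2 to compound 3 (1.78 log units; beyond the scatter).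

Compound 4 `CC(C)c1cc(N)c2cc(NC(=O)/C=C/c3ccc(C(F)(F)F)cc3)ccc2n1` has not yet been measured. It differs from compound 3 in one place: isopropyl in place of phenyl on an aromatic carbon. The phenyl leaves and a small branched chain enters, so the step largely undoes the change that separated compound 2 from compound 3. For the measured compounds named here, the one measured step that bears on it is that same large one, and compound 1, which carries a propyl group on the same aromatic carbon, sits close to compound 2. He therefore expects a large drop in this assay, with the number for compound 4 expected to return toward those of compound 1 and compound 2, the expected step being a 33-fold lower number from compound 3 to compound 4 (1.52 log units; beyond the scatter). His estimate for compound 4 is 200 nM, expected to lie between 60 nM and 700 nM.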

Compound 4, half-maximal effective concentration: 160 nM
For compound 4 the middle estimate is 1.3-fold (0.10 log units) above the measured one, and the stated range covers the measured number.
By their numbers in this assay, from the lowest: compounds 2, 1 and 4 (each within the scatter of the next); then compound 3.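

In this assay, isopropyl in place of phenyl on the aromatic carbon next to the ring nitrogen brings a 41-fold lower number from compound 3 to compound 4 (1.62 log units; beyond the scatter) and so recovers nearly all of what the phenyl group had cost. This shows that the position does not demand a straight chain: with the amino group and the rest of the shared core unchanged, the branched isopropyl group is tolerated as well as ethyl, since the added methyl gives a 1.5-fold higher number from compound 2 to compound 4 (0.16 log units; within the scatter) and leaves the two compounds indistinguishable on this read-out. The data at hand give no reason for the wide gap between the phenyl group and the two chains at this carbon.

From the compounds shown here alone, what stays open is whether the loss seen with phenyl follows from the aromatic ring itself or simply from the larger number of carbon atoms, a question that a cyclohexyl group on the same carbon would address. Going by these compounds, it is also open how far the position tolerates growth among chains, as a tert-butyl group or a longer chain such as butyl would show.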